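The source may report more compounds than this note shows. Statements on the series, on what has been measured and on what is new or still open speak of the compounds shown alone.

Series notes on the shared core of compound 1 `Oc1ccc(CNc2cc(C(F)(F)F)cc3[nH]ncc23)cc1`. Among the compounds with values here, in an assay for inhibition of Indoleamine 2,3-dioxygenase 1 (Homo sapiens), with stated times of 10 min and 60 min, tested at 100 uM (on this read-out lower numbers stand for a weaker effect and higher numbers for a stronger effect at the one concentration tested), compound 1 gives 81%, the highest of the three numbers so far. Within the data shown here, compound 3 `O=[N+]([O-])c1ccc(CNc2cc(C(F)(F)F)cc3[nH]ncc23)cc1` gives 61% in this assay, and its single change, nitro in place of hydroxy on an aromatic carbon, is a number 20 percentage points lower from compound 1 to compound 3 (beyond the scatter). Among the measured compounds shown here, compound 2 `FC(F)(F)c1cc(NCc2cccc3sccc23)c2cn[nH]c2c1` gives 3% in this assay; no step to compound 1 is computed for this pair, but its number lies far beneath that of compound 1.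

Compound 4 `FC(F)(F)c1cc(NC[C@H]2CCCN2)c2cn[nH]c2c1` is not yet measured. Its change from compound 1 is pyrrolidin-2-yl in place of 4-hydroxyphenyl on a saturated chain carbon bound to a nitrogen on an aromatic ring. For the measured compounds named here, no measured step covers this exchange directly. The step from compound 1 to compound 3 bears on it only in that altering the hydroxy of the 4-hydroxyphenyl already costs a modest amount, and compound 2 shows that a different ring in the same place can leave almost no inhibition. The present exchange goes further, since the six-membered aromatic ring of carbon only leaves entirely, so a sizeable fall is expected. The estimate for compound 4 in this assay is 25%, within 5% to 55%. The expected step is a number 56 percentage points lower from compound 1 to compound 4 (beyond the scatter).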

Compound 4, a percentage reported as inhibition, at one concentration (the size of the read-out at that concentration, not a potency): 83%
The estimate for compound 4 lay 58 percentage points below the measured number; measured number outside the range, above it.
By their numbers in this assay, from the lowest: compound 2; then compound 3; then compounds 1 and 4 (each within the scatter of the next).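

In this assay, pyrrolidin-2-yl in place of 4-hydroxyphenyl gives a number 2 percentage points higher from compound 1 to compound 4 (within the scatter), so a six-membered aromatic ring of carbon only is not needed on this saturated chain carbon bound to a nitrogen on an aromatic ring. The earlier compounds shown here could not show this, since each carries an aromatic ring at this place and compound 2 gives only 3%. Nothing measured here accounts for the result.

As far as these compounds go, it remains open whether the ring nitrogen and the defined stereocentre of pyrrolidin-2-yl matter, which the opposite stereoisomer, a piperidin-2-yl group or an open-chain amine at this place would test. From the compounds shown here alone, these numbers come from one concentration, so any difference in potency between compound 1 and compound 4 also remains open.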